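The compounds below may be only part of what the source reports. "The series", "measured", "known", "first", "only" and "open" are said of these compounds alone.

Measured compounds:
compound 1 `c1csc(-c2ccccc2NCC2=NCCN2)c1` — 2.24 nM
compound 2 `c1ccc(-c2cnccn2)c(NCC2=NCCN2)c1` — 4.57 nM

Both numbers come from a functional assay for activation of Alpha-1A adrenergic receptor (Homo sapiens), read by calcium flux; a lower number here means that less compound is needed, a higher number that more compound is needed for the effect. Among the two values on hand, compound 2 stands highest: its nearest neighbour is compound 1, and the step of a 2.0-fold higher number from compound 1 to compound 2 (0.31 log units; beyond the scatter) separates them, so compound 2 needs somewhat more material than compound 1 for the same effect.

Compound 3 `c1cnc(-c2ccccc2NCC2=NCCN2)nc1` has not yet been measured. It differs from compound 2 in one place: pyrimidin-2-yl in place of pyrazin-2-yl on an aromatic carbon. Within the data shown here, only one measured step exists, the one from compound 1 to compound 2, and it swapped a five-membered ring for a six-membered one while leaving the rest of the molecule untouched; it was modest in size. Among the measured compounds shown here, no measured pair shows what happens when one six-membered ring with two nitrogen atoms is exchanged for another, so that step bears on the present change only loosely. The expectation for compound 3 in this assay is therefore a change of about a 1.1-fold higher number from compound 2 to compound 3 (0.04 log units; within the scatter), essentially none beyond the scatter. Compound 3 is estimated at 5 nM, with a range from 2 nM to 14 nM.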

Compound 3, half-maximal effective concentration: 10 nM
Beside the measured number, compound 3's estimate is 2.0-fold (0.30 log units) below it, within the range that was stated.
By their numbers in this assay, from the lowest: compound 1; then compound 2; then compound 3.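

In this assay, putting pyrimidin-2-yl in place of pyrazin-2-yl comes with a 2.2-fold higher number from compound 2 to compound 3 (0.34 log units; beyond the scatter), so this position responds even when the entering group has the same heavy atoms, the same ring size and the same counts of hydrogen-bond donors and acceptors as the group that leaves. Against the thiophen-2-yl group, the pyrimidin-2-yl group gives a 4.5-fold higher number from compound 1 to compound 3 (0.65 log units; beyond the scatter), which makes compound 3 the compound that needs the most material of the three, and every step among them lies beyond the scatter. Nothing available explains why the arrangement of the ring atoms matters here, and no measurement bears on the reason for this shift.

On these data alone, it remains open whether a ring with a single nitrogen, such as pyridin-2-yl, or a plain phenyl ring at the same aromatic carbon would fall within the span of these three numbers or outside it. As far as these compounds go, it also remains open whether a non-aromatic group at this place, such as an amine or a short alkyl chain, would be tolerated in this assay, since all three compounds carry an aromatic ring there.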